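The source may hold more compounds than are shown below. What is called first, only, known or untested is meant among the compounds shown, and "the series" means these compounds.

Series notes. In a functional assay on K562 cells (Homo sapiens) for cytotoxicity, read by trypan blue exclusion, with a stated time of 96 h (on this read-out higher numbers stand for weaker inhibition and lower numbers for stronger inhibition), compound 1 `COc1cc(OC)c(/C=C/S(=O)(=O)Cc2ccc(OC)c([N+](=O)[O-])c2)c(OC)c1` gives 2500 nM, compound 2 `COc1cc(OC)c(/C=C/S(=O)(=O)Cc2ccc(OC)c(N)c2)c(OC)c1` gives 2.5 nM and compound 3 `COC(=O)CNc1cc(CS(=O)(=O)/C=C/c2c(OC)cc(OC)cc2OC)ccc1OC` gives 100 nM. Compound 3 therefore stands second highest of the three numbers, set by a 25-fold lower number from compound 1 to compound 3 (1.40 log units; beyond the scatter) and by a 40-fold higher number from compound 2 to compound 3 (1.60 log units; beyond the scatter). Compound 4 `COC(=O)CCNc1cc(CS(=O)(=O)/C=C/c2c(OC)cc(OC)cc2OC)ccc1OC` differs from compound 3 by (methoxycarbonyl)methyl in place of methoxycarbonyl on a saturated chain carbon bound to a nitrogen on an aromatic ring. Going by the values given here, no measured step lengthens the chain on the nitrogen. The nearest comparison is a 40-fold higher number from compound 2 to compound 3 (1.60 log units; beyond the scatter), where (methoxycarbonyl)methyl entered in place of hydrogen on a nitrogen on an aromatic ring, while a 1000-fold lower number from compound 1 to compound 2 (3.00 log units; beyond the scatter) concerns the nitro-to-amino exchange and does not bear on this step. With the group on nitrogen kept and only extended by one chain carbon, no step beyond the scatter is expected in this assay: no change at the digits printed from compound 3 to compound 4 (within the scatter). For compound 4 the estimate is 100 nM, range 30 nM to 400 nM.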

Compound 4, half-maximal inhibitory concentration: 1000 nM
Beside the measured number, compound 4's estimate is 10-fold (1.00 log units) below it; measured number above the stated range.
By their numbers in this assay, from the lowest: compound 2; then compound 3; then compound 4; then compound 1.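

In this assay, the substituent on the aromatic amine proves sensitive to chain length: 2-(methoxycarbonyl)ethyl in place of (methoxycarbonyl)methyl gives a 10-fold higher number from compound 3 to compound 4 (1.00 log units; beyond the scatter). The ester-bearing chain now costs more against the free amine, with a 400-fold higher number from compound 2 to compound 4 (2.60 log units; beyond the scatter), and keeps less of the advantage over the nitro group, with a 2.5-fold lower number from compound 1 to compound 4 (0.40 log units; beyond the scatter). No evidence on the cause of this sensitivity is at hand. Open, on these data alone, is whether a longer chain moves the number further. Also open, as far as these compounds go, is how the carboxylic acid in place of the methyl ester behaves on either chain.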